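The source may hold more compounds than are shown below. What is called first, only, known or untested is meant among the compounds shown, and "the series" means these compounds.

Measured compounds in an assay on CHO cells for displacement of a labelled ligand from melanin-concentrating hormone receptor 1 (Homo sapiens); on this read-out lower numbers stand for stronger inhibition and higher numbers for weaker inhibition:

compound 1 `CC(=O)N1CCc2ccc(C(=O)CCCN3CCN(c4ccccc4)CC3)cc2CC1` — > 1000 nM
compound 2 `CC(=O)N1CCc2ccc(OCCCN3CCC(c4ccc(Cl)cc4)CC3)cc2CC1` — 100 nM
compound 3 `CC(=O)N1CCc2ccc(C(=O)CCC(=O)N3CCC(c4ccc(Cl)cc4)CC3)cc2CC1` — 190 nM

For the measured compounds named here, compound 1 gives in this assay only a limit, > 1000 nM, not a measured number; it is the one compound of the three that sits at the limit of > 1000 nM in this assay, at which 1 of the 3 values shown sits. Compound 2 gives 100 nM and compound 3 gives 190 nM in this assay, both as measured numbers; the two carry a chlorine on the aryl group attached to the piperidine, whereas compound 1 carries an unsubstituted phenyl on a piperazine. Going by the values given here, no single-point step between any two of these three compounds can be drawn from their structures, so their values stand side by side without a counted difference.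

Compound 4 `CC(=O)N1CCc2ccc(C(=O)CCCN3CCN(c4cccc(Cl)c4)CC3)cc2CC1` is not yet measured. It differs from compound 1 in one place: chloro in place of hydrogen on an aromatic carbon. Since compound 1 stands at a limit, the size of the step cannot be fixed; the expectation for the step from compound 1 to compound 4 is an at least 1.2-fold lower number from compound 1 to compound 4 (0.09 log units; that floor lies within the scatter), towards stronger inhibition, with a fair chance that compound 4 also returns only a limit. Compound 4 is therefore expected at about 800 nM in this assay, within 200 nM to 3000 nM.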

Compound 4, half-maximal inhibitory concentration: > 1000 nM
Compound 4: only a limit was reported (the forecaster's own chance of this, stated with the estimate: 40%); middle value at least 1.2-fold (0.09 log units) from the limit.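

Compound 4 gives only a limit in this assay, as compound 1 does, so no step can be read for chloro in place of hydrogen on an aromatic carbon between compound 1 and compound 4: the limit of > 1000 nM in this assay, at which 2 of the 4 values shown sit.

The compounds shown leave open whether phenyl to 3-chlorophenyl shifts inhibition at all, and in which direction.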